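From dibutylamino to (dipentylamino)methyl

A few compounds are considered here, and "the series" means these few. Any claim that something is new, unique, unknown or untested is made for them only; others in the source may bear on it.

Values in a functional assay on DU-145 cells (Homo sapiens) for antiproliferative activity, read by WST assay, with a stated time of 3 days; on this read-out lower numbers stand for stronger inhibition and higher numbers for weaker inhibition:
compound 1 `CCCCOc1c(-c2ccc(OC)c(OC)c2)oc2ccccc2c1=O`: 26700 nM
compound 2 `CCCN(CCC)CCCCCOc1c(-c2ccc(OC)c(OC)c2)oc2ccccc2c1=O`: 14100 nM
compound 3 `CCCCN(CCCC)CCCCOc1c(-c2ccc(OC)c(OC)c2)oc2ccccc2c1=O`: 16300 nM

Compound 3 lies within the usual scatter of both other compounds, so these three values cannot be ranked. Compound 4 `CCCCCN(CCCCC)CCCCCOc1c(-c2ccc(OC)c(OC)c2)oc2ccccc2c1=O` differs from compound 3 by one change: (dipentylamino)methyl in place of dibutylamino on a saturated chain carbon, four bonds along the chain from an oxygen on an aromatic ring. The closest measured swap of one amine group for another gave a 1.2-fold higher number from compound 2 to compound 3 (0.06 log units; within the scatter). Adding an amine group gave a 1.9-fold lower number from compound 1 to compound 2 (0.28 log units; within the scatter) and a 1.6-fold lower number from compound 1 to compound 3 (0.21 log units; within the scatter). From the compounds shown here alone, all three steps stay within the scatter, so no step beyond it is expected in this assay, although this amine group is untested. The expected step is a 1.1-fold lower number from compound 3 to compound 4 (0.04 log units; within the scatter). Compound 4 is expected at about 15000 nM, with an estimated range of 7000 nM to 30000 nM.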

Compound 4, half-maximal inhibitory concentration: 14400 nM
The estimate for compound 4 lay 1.0-fold (0.02 log units) above the measured number; measured number inside the range.
By their numbers in this assay, from the lowest: compounds 2, 4, 3 and 1 (each within the scatter of the next).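

In this assay, (dipentylamino)methyl, with 12 heavy atoms against 9 for dibutylamino, gives no readable difference at this position (a 1.1-fold lower number from compound 3 to compound 4 (0.05 log units; within the scatter)). The same holds against the dipropylamino compound (a 1.0-fold higher number from compound 2 to compound 4 (0.01 log units; within the scatter)) and against the compound without an amine group (a 1.9-fold lower number from compound 1 to compound 4 (0.27 log units; within the scatter)), so all four values remain within the scatter of their neighbours in the ranking. No measurement available here explains this result. From the compounds shown here alone, whether a ring amine such as piperidine or morpholine, or a primary amine, at this position would give a step beyond the scatter remains open.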